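A few compounds are considered here, and "the series" means these few. Any claim that something is new, unique, unknown or untested is made for them only; others in the source may bear on it.

In an ADME assay on MRC5 cells (Homo sapiens), read by MTT assay, with a stated time of 72 h; a higher number here means a weaker inhibitor, a lower number a stronger inhibitor:
- compound 1 `CSc1ncnc2c1c(-c1cccs1)cn2[C@@H]1O[C@H](CO)[C@@H](O)[C@H]1O`: > 100000 nM
- compound 2 `CSc1ncnc2c1c(-c1ccsc1)cn2[C@@H]1O[C@H](CO)[C@@H](O)[C@H]1O`: > 100000 nM

Compound 2 has no numerical value, only the limit > 100000 nM. Among the measured compounds shown here, the series so far offers just one reference point: the limit of > 100000 nM in this assay, at which 2 of the 2 values shown sit.

Compound 3 `C#Cc1cn([C@@H]2O[C@H](CO)[C@@H](O)[C@H]2O)c2ncnc(SC)c12` carries ethynyl in place of thiophen-3-yl on an aromatic carbon of the shared core: ethynyl in place of thiophen-3-yl on an aromatic carbon.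

For the measured compounds named here, the only measured step bearing on this change is a step that the two limits leave unreadable from compound 1 to compound 2. It exchanges one thiophene attachment for another, and it provides no size to carry over to a change from thiophen-3-yl to ethynyl. Compound 3 is therefore expected most likely to stay at the limit in this assay, with any measurable number implying a stronger inhibitor. The expected change is an at least 2.0-fold lower number from compound 2 to compound 3 (0.30 log units; that floor lies within the scatter). For compound 3 the estimated value is 50000 nM, with an expected range of 8000 nM to 100000 nM.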

Compound 3, half-maximal inhibitory concentration: > 100000 nM
Compound 3: no number, only a limit; the forecaster's own chance of this, stated with the estimate: 65%; middle value at least 2.0-fold (0.30 log units) away from the limit.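

Compound 3, like compound 1 and compound 2, gives only a limit in this assay, so no step among these three compounds can be read: the limit of > 100000 nM in this assay, at which 3 of the 3 values shown sit.

The compounds shown leave open whether any group at this place on the shared core gives a measurable value, and how far thiophen-2-yl, thiophen-3-yl and ethynyl would differ.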